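Title: From chloro-methylphenyl to trimethylphenyl anilide

A few compounds are considered here, and "the series" means these few. Any claim that something is new, unique, unknown or untested is made for them only; others in the source may bear on it.

Compound 3 `CCN(CC)CCCOc1cc2ncnc(Nc3nc4ccc(C(=O)Nc5c(C)cccc5Cl)cc4s3)c2cc1OC` is measured in a functional assay on HCT-116 cells (Homo sapiens) for cytotoxicity, read by WST assay, with a stated time of 72 h (on this read-out lower numbers stand for stronger inhibition and higher numbers for weaker inhibition), where compound 3 gives 13200 nM. Among the numbers shown this is the highest of two; the nearest is compound 1 `COc1cc2c(Nc3nc4ccc(C(=O)Nc5c(C)cc(C)cc5C)cc4s3)ncnc2cc1OCCCN1CCC(C)CC1`, which in this assay gives 6900 nM, a gap within the scatter. Compound 2 `CCN(CC)CCCOc1cc2ncnc(Nc3nc4ccc(C(=O)Nc5c(C)cccc5C)cc4s3)c2cc1OC` returns only a limit of the assay, > 100000 nM, in this assay.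

The change to compound 4 `CCN(CC)CCCOc1cc2ncnc(Nc3nc4ccc(C(=O)Nc5c(C)cc(C)cc5C)cc4s3)c2cc1OC` is 2,4,6-trimethylphenyl in place of 2-chloro-6-methylphenyl on an amide-type nitrogen. Going by the values given here, one measured step bears on the anilide portion: an at least 7.5-fold lower number from compound 2 to compound 3 (0.87 log units; beyond the scatter). Compound 4 moves in the opposite direction at that position, methyl replacing chloro, while also carrying the additional methyl of the 2,4,6-trimethylphenyl group. Compound 1 carries the same trimethylphenyl amide with a different amine chain and gives a number within the scatter of compound 3. Compound 4 is therefore expected to land near compound 3, with an uncertain drift toward higher numbers, an expected step of a 1.1-fold higher number from compound 3 to compound 4 (0.06 log units; within the scatter). The estimate for compound 4 is 15000 nM, with a range from 4000 nM to 80000 nM.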

Compound 4, half-maximal inhibitory concentration: 7500 nM
For compound 4 the middle estimate is 2.0-fold (0.30 log units) above the measured one; the range from low to high includes it.
By their numbers in this assay, from the lowest: compounds 1, 4 and 3 (each within the scatter of the next). At a limit, above all of these: compound 2.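

In this assay, 2,4,6-trimethylphenyl and 2-chloro-6-methylphenyl on the amide-type nitrogen cannot be told apart, with a 1.8-fold lower number from compound 3 to compound 4 (0.25 log units; within the scatter), and with that anilide in place, diethylamino and 4-methylpiperidin-1-yl on the chain cannot be told apart either, with a 1.1-fold higher number from compound 1 to compound 4 (0.04 log units; within the scatter). The clear new finding is that a single methyl in place of hydrogen on an aromatic carbon of the anilide separates two compounds, with an at least 13-fold lower number from compound 2 to compound 4 (1.12 log units; beyond the scatter). That step is a bound and not an exact size, since compound 2 gives only a limit of the assay: the limit of > 100000 nM in this assay, at which 1 of the 4 values shown sits.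

On these data alone, it remains open whether a 2-chloro-4,6-dimethylphenyl amide would stay at this level or move away from it. As far as these compounds go, it is also open whether a morpholine at the end of the chain would match diethylamino and 4-methylpiperidin-1-yl.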